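Working notes: from compound 3 to compound 4

The compounds below may be only part of what the source reports. "The series", "measured", "known", "first", "only" and "open" are said of these compounds alone.

Measured so far in a functional assay on HeLa cells (Homo sapiens) for cytotoxicity, read by MTT assay, in the presence of a further agent that is not named here; a higher number here means a weaker inhibitor, a lower number a stronger inhibitor
- compound 1 `O=C1CC(CCc2ccccc2)[S+]([O-])S1` gives 24800 nM
- compound 2 `CC(C)(C)[Si](C)(C)O[C@@H]1[C@H](O[Si](C)(C)C(C)(C)C)[C@@H](C2CC(=O)SS2)O[C@H]1n1ccc(=O)[nH]c1=O` gives 7840 nM
- compound 3 `Cc1cn([C@H]2C[C@H](O[Si](C)(C)C(C)(C)C)[C@@H](C3CC(=O)SS3)O2)c(=O)[nH]c1=O` gives 16700 nM

Compound 3 lies within the scatter of compound 1, while compound 2 has a lower number, beyond the scatter. Unmeasured compound 4 `Cc1cn([C@H]2C[C@H](O[Si](C)(C)C(C)(C)C)[C@@H](C3CC(=O)S[S+]3[O-])O2)c(=O)[nH]c1=O` carries this change: a group of 7 heavy atoms (3 carbon, 2 oxygen, 2 sulfur; one five-membered non-aromatic ring with 2 hetero atoms) in place of a group of 6 heavy atoms (3 carbon, 1 oxygen, 2 sulfur; one five-membered non-aromatic ring with 2 hetero atoms), on a saturated ring carbon, on a saturated ring carbon of a five-membered non-aromatic ring with 1 oxygen. Among the compounds with values here, no measured pair isolates the change. Within the data shown here, compound 1, the only measured compound with the entering group, gives 24800 nM in this assay, within the scatter of compound 3. No step beyond the scatter is therefore expected, in either direction. The estimated change is a 1.1-fold lower number from compound 3 to compound 4 (0.05 log units; within the scatter). For compound 4 the expected value is 15000 nM, with an estimated range of 6500 nM to 34000 nM.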

Compound 4, half-maximal inhibitory concentration: 6610 nM
For compound 4 the middle estimate is 2.3-fold (0.36 log units) above the measured one, and the stated range covers the measured number.
By their numbers in this assay, from the lowest: compounds 4 and 2 (each within the scatter of the next); then compounds 3 and 1 (each within the scatter of the next).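

In this assay, the group of 7 heavy atoms in place of the group of 6 heavy atoms, on the saturated ring carbon next to the ring oxygen, gives a 2.5-fold lower number from compound 3 to compound 4 (0.40 log units; beyond the scatter). Within the data shown here, this is the only pair that isolates the change, and it shows that a change at this position can move the number beyond the scatter. Nothing at hand accounts for the step.

From the compounds shown here alone, whether the same change gives a similar step on the core of compound 2 remains open. Also open, going by these compounds, is how an amine or a carboxylic acid would fare at this ring carbon.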